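A Bicyclic Group Replaces the Aminopyridine Arm

A few compounds are considered here, and "the series" means these few. Any claim that something is new, unique, unknown or untested is made for them only; others in the source may bear on it.

Compound 1, `O=C1[C@@H](NS(=O)(=O)c2nc3cc(Cl)ccc3[nH]2)CCN1CCNc1ccncc1`, was tested in an assay on isolated protein for inhibition of coagulation factor X (Oryctolagus cuniculus), tested at 1 uM (a lower number here means less inhibition, a higher number more inhibition at the concentration tested (going by the name of the read-out)), where compound 1 gives 29%. This is the lower of the two numbers in hand, but the other, from compound 2, `O=C1[C@@H](NS(=O)(=O)c2cc3c(Cl)nccc3s2)CCN1Cc1cc2c[nH]ccc-2n1`, lies close: in this assay compound 2 gives 35%, and the two values fall within the scatter of each other, so no order between them can be claimed. Among the measured compounds shown here, compound 2 also differs from compound 1 in more than one place, so no single step links the two measured compounds.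

Compound 3, `O=C1[C@@H](NS(=O)(=O)c2nc3cc(Cl)ccc3[nH]2)CCN1Cc1cc2[nH]cccc-2n1`, has not yet been measured. It differs from compound 1 in one place: a group of 9 heavy atoms (7 carbon, 2 nitrogen; one five-membered aromatic ring with 1 hetero atom, one six-membered aromatic ring with 1 hetero atom) in place of a group of 8 heavy atoms (6 carbon, 2 nitrogen; one six-membered aromatic ring with 1 hetero atom), on a saturated chain carbon bound to an amide-type nitrogen in a ring. For the measured compounds named here, no measured pair shows what this exchange does, so the direction of the step in this assay is open. A step of modest size, not clearly beyond the scatter and somewhat more likely upward than downward, is expected. Compound 3 is estimated to give 38%, within 15% and 65%. The expected step of a number 9 percentage points higher from compound 1 to compound 3 (within the scatter) stays near the scatter.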

Compound 3, a percentage reported as inhibition, at one concentration (the size of the read-out at that concentration, not a potency): 14%
Compound 3: middle estimate off by 24 percentage points, on the high side; the measured number lies below the stated range.
By their numbers in this assay, from the lowest: compound 3; then compounds 1 and 2 (each within the scatter of the next).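

The exchange at this position, on a saturated chain carbon bound to an amide-type nitrogen in a ring, now has a measured direction: in this assay, replacing the ((pyridin-4-yl)amino)methyl group with the group holding one five-membered and one six-membered aromatic ring gives a number 15 percentage points lower from compound 1 to compound 3 (beyond the scatter). With the rest of compound 1 kept, this single place is therefore enough to move the read-out beyond the usual scatter, which the earlier pair could not show, as its members differ in more than one place. The exchange alters several things at once, including the ring count and the hydrogen-bond acceptors, from 2 to 1, and nothing at hand bears on what lies behind the step.

One step at one concentration gives no measure of potency and cannot separate the contributions of the added five-membered ring and the lost chain amine. It also leaves open how a plain benzyl group, or a longer chain ending in a primary amine, would read on the same carbon, and whether the step would hold on the core of compound 2.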